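A few compounds are considered here, and "the series" means these few. Any claim that something is new, unique, unknown or untested is made for them only; others in the source may bear on it.

Of the compounds shown here, three sharing one core have been measured in a functional assay on V79 cells (Cricetulus griseus) for cytotoxicity, read by colony formation; a lower number here means a stronger inhibitor, a higher number a weaker inhibitor. Compound 1 `O=C(O)c1cn(C2CC2)c2c(F)c(N3CCNCC3)c(F)cc2c1=O` gives 47 ug/mL and compound 2 `COc1c(N2CCNCC2)c(F)cc2c(=O)c(C(=O)O)cn(C3CC3)c12` gives 82 ug/mL. Methoxy in place of fluoro on an aromatic carbon thus gives a 1.7-fold higher number from compound 1 to compound 2 (0.24 log units; within the scatter). Compound 3 `O=C(O)c1cn(C2CC2)c2c(C(F)(F)F)c(N3CCNCC3)c(F)cc2c1=O` stands apart at 1650 ug/mL, the highest number of the three, which makes it the weakest inhibitor here. Trifluoromethyl in place of fluoro gives a 35-fold higher number from compound 1 to compound 3 (1.55 log units; beyond the scatter), and trifluoromethyl in place of methoxy gives a 20-fold higher number from compound 2 to compound 3 (1.30 log units; beyond the scatter).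

Compound 4 `CC1CN(c2c(F)cc3c(=O)c(C(=O)O)cn(C4CC4)c3c2C(F)(F)F)CCN1` keeps the trifluoromethyl of compound 3 but carries methyl in place of hydrogen on a saturated ring carbon, turning piperazin-1-yl into 3-methylpiperazin-1-yl: methyl in place of hydrogen on a saturated ring carbon. For the measured compounds named here, none of the measured steps touches this ring, since all three are exchanges on an aromatic carbon. They show that one exchange elsewhere on the core can move the number a long way, but they give no size or direction for this one. With no evidence for a shift, the reasonable starting point is compound 3 at 1650 ug/mL, and no change beyond the scatter is expected. The expected step is a 1.2-fold lower number from compound 3 to compound 4 (0.07 log units; within the scatter). For compound 4 the estimated value is 1400 ug/mL, with an expected range from 500 ug/mL to 3000 ug/mL.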

Compound 4, half-maximal inhibitory concentration: 220 ug/mL
Estimate against measurement, compound 4: 6.4-fold (0.80 log units) above; measured number outside the range, below it.
By their numbers in this assay, from the lowest: compounds 1 and 2 (each within the scatter of the next); then compound 4; then compound 3.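

In this assay, turning piperazin-1-yl into 3-methylpiperazin-1-yl gives a 7.5-fold lower number from compound 3 to compound 4 (0.88 log units; beyond the scatter) and so moves the number towards stronger inhibition by more than the scatter. For the compounds shown here, every earlier step was an exchange on an aromatic carbon, so this is the first sign that the number also responds to a change on the six-membered non-aromatic ring, on a saturated ring carbon next to the ring nitrogen. Nothing available here bears on the reason for this step.

Going by these compounds, this reading rests on a single pair of compounds with trifluoromethyl on the aromatic carbon, so it remains open whether the same methyl would shift the number by a similar amount, or in the same direction, on compound 1 with its fluoro or compound 2 with its methoxy. Also open, on these data alone, is how the number would respond if that saturated ring carbon carried something other than methyl, such as an ethyl group, a longer chain, a hydroxymethyl group or an amine.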